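A few compounds are considered here, and "the series" means these few. Any claim that something is new, unique, unknown or untested is made for them only; others in the source may bear on it.

Measured so far:
Compound 1, `COc1ccc(C(=O)NC(=S)Nc2cccc(-c3nc4ccccc4[nH]3)c2)cc1OC`: 6000 nM
Compound 2, `N#Cc1ccc2[nH]c(-c3cccc(NC(=S)NC(=O)c4ccc5c(c4)OCCO5)c3)nc2c1`: 1000 nM
Compound 3, `CCOc1ccc(C(=O)NC(=S)Nc2cc(-c3nc4ccccc4[nH]3)ccc2C)cc1OCC`: "not determined" (no result reported)

In a functional assay on HUVEC cells (Homo sapiens) for cytotoxicity, read by WST assay, with a stated time of 48 h (on this read-out higher numbers stand for weaker inhibition and lower numbers for stronger inhibition), compound 1 gives 6000 nM, the higher of the two numbers shown and so the weaker inhibitor; compound 2 gives 1000 nM, a gap beyond the usual scatter. Compound 3 has no result in this assay. Compound 4, `O=C(NC(=S)Nc1cccc(-c2nc3ccccc3[nH]2)c1)c1ccccc1`, differs from compound 1 in one place: phenyl in place of 3,4-dimethoxyphenyl on a carbonyl carbon. No measured pair differs by this change alone, so its effect cannot be read from the numbers shown. The step of a 1.3-fold higher number from compound 1 to compound 4 (0.12 log units; within the scatter) is expected to be small and towards weaker inhibition. Compound 4 is expected to give about 8000 nM in this assay, with a likely range from 2500 nM to 25000 nM.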

Compound 4, half-maximal inhibitory concentration: > 10000 nM
Compound 4 gave a limit, no number (the forecaster's own chance of this, stated with the estimate: 20%); at least 1.2-fold (0.09 log units) between middle value and limit.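

In this assay, within the data shown here, phenyl in place of 3,4-dimethoxyphenyl on a carbonyl carbon gives an at least 1.6-fold higher number from compound 1 to compound 4 (0.22 log units; that floor lies within the scatter), the first step that can be read at this position. Compound 4 gives a limit and not a number: the limit of > 10000 nM in this assay, at which 1 of the 4 values shown sits. As far as these compounds go, the true size of the step therefore stays unknown, and the data show only that removing the two methoxy groups brought no stronger inhibition.

From the compounds shown here alone, it remains open whether a single methoxy group on the phenyl ring would match the 3,4-dimethoxyphenyl of compound 1. Also open, going by these compounds, is what an amine or a carboxylic acid on that ring would give.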